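Shortening the nitrooxy chain of compound 1

A few compounds are considered here, and "the series" means these few. Any claim that something is new, unique, unknown or untested is made for them only; others in the source may bear on it.

Values measured in a functional assay on HOP-62 cells (Homo sapiens) for cytotoxicity, read by resazurin assay, with a stated time of 72 h (on this read-out higher numbers stand for weaker inhibition and lower numbers for stronger inhibition), follow.
- compound 1 `COc1cc(/C=C/C(=O)OCCCCCCO[N+](=O)[O-])ccc1O` gives > 50000 nM (a limit)
- compound 2 `O=C(/C=C/c1ccc(O)c(O)c1)OCc1c(-c2ccccc2)no[n+]1[O-]` gives 6120 nM (a number)
- compound 3 `O=C(/C=C/c1ccc(OCCCCCCO[N+](=O)[O-])c(O)c1)OCCCCCCO[N+](=O)[O-]` gives > 50000 nM (a limit)

Compound 1 stands at the limit of > 50000 nM in this assay, at which 2 of the 3 values shown sit, and so carries a limit and no number. Compound 3 carries a limit as well, and compound 2 alone gives a number.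

Compound 4 `COc1cc(/C=C/C(=O)OCCCO[N+](=O)[O-])ccc1O` keeps the core of compound 1. The change nitrooxy in place of 3-(nitrooxy)propyl on a saturated chain carbon, three bonds along the chain from an oxygen next to a carbonyl group puts nitrooxy in place of 3-(nitrooxy)propyl on a saturated chain carbon, three bonds along the chain from an oxygen next to a carbonyl group.

Going by the values given here, no measured step gives the size of this change. The expectation rests on compound 1, whose > 50000 nM is a limit. No step beyond the scatter is expected in this assay and no direction is assigned. The estimated step of a number no higher from compound 1 to compound 4 (the limit leaves the size open) is expected to stay within the scatter. For compound 4 the estimate is 50000 nM with 20000 nM to 100000 nM as the expected range.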

Compound 4, half-maximal inhibitory concentration: 19400 nM
Beside the measured number, compound 4's estimate is 2.6-fold (0.41 log units) above it; the whole stated range lies above it.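

In this assay, shortening the chain gives an at least 2.5-fold lower number from compound 1 to compound 4 (0.41 log units; beyond the scatter), so the length of the nitrooxy chain at this position can change the read-out beyond the scatter. Among the compounds with a nitrooxy chain, compound 4 is the only one that gives a number and not a limit. The full size of the step stays open, since its starting point is only a limit: the limit of > 50000 nM in this assay, at which 2 of the 4 values shown sit.

From the compounds shown here alone, compound 1 and compound 4 alone describe this chain change, so it remains open whether the number keeps dropping with a still shorter chain or where along the chain it starts to move. Going by these compounds, it is also open whether the nitrooxy group matters here or chain length alone does; an amine or a carboxylic acid at the chain end would separate the two.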